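This account rests on a few compounds, and the source may have more. Where it says the series, first, only, none or still open, it means among the compounds named here.

Of the compounds shown here, three on a shared core have been tested in a functional assay on HT-29 cells (Homo sapiens) for cytotoxicity, read by sulforhodamine B assay, with a stated time of 72 h; a higher number here means a weaker inhibitor of growth, a lower number a stronger inhibitor of growth. Compound 1 `COC(=O)[C@@]1(C)CCC[C@]2(C)C(CCc3ccc4c(OC)ccc(OC)c4c3)=C(OOC(C)(C)C)CC[C@@H]12` carries a (tert-butoxy)oxy group on a double-bonded ring carbon. Compound 1 reads > 18600 nM, which is a limit of the assay and not a number. Compound 2 `C=C1CC[C@@H]2[C@](C)(CCC[C@]2(C)C(=O)OC)[C@]1(O)CCc1ccc2c(OC)ccc(OC)c2c1` reads > 21500 nM, and this too is a limit. Compound 3 `C=C1C(=O)C[C@@H]2[C@](C)(CCC[C@]2(C)C(=O)OC)[C@H]1CCc1ccc2c(OC)ccc(OC)c2c1` is the only one of the three with a number, at 3200 nM. Compound 1 therefore stands at a limit, with no measured potency of its own.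

Compound 4 `COC(=O)[C@@]1(C)CCC[C@]2(C)C(CCc3ccc4c(OC)ccc(OC)c4c3)=C(C)CC[C@@H]12` has not yet been measured. It differs from compound 1 in one place, with methyl in place of (tert-butoxy)oxy on a double-bonded ring carbon. No measured pair among these compounds shows this change, so the expectation rests on the limit of compound 1 alone. In this assay no step beyond the scatter is expected, and another limit is the likelier reading. The estimated change is small, as an at least 1.0-fold lower number from compound 1 to compound 4 (0.01 log units; that floor lies within the scatter). For compound 4 the expected concentration for growth inhibition is estimated at 18000 nM, within an expected range from 6000 nM to 40000 nM.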

Compound 4, concentration for 50% growth inhibition: > 6700 nM
Compound 4: a limit, no number; the forecaster's own chance of this, stated with the estimate: 65%; the middle value lies beyond the limit too.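

Compound 1 and compound 4 both stand at limits in this assay, not at numbers, so the step of methyl in place of (tert-butoxy)oxy cannot be read. The compounds shown leave open how strongly compound 1 and compound 4 inhibit growth, and whether this change in one place alters that at all.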